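From pyridin-3-yl to pyridin-4-yl on a shared core

This account rests on a few compounds, and the source may have more. Where it says the series, first, only, none or still open, it means among the compounds named here.

- compound 1 `CNC(=O)c1cc(C(=O)N[C@H]2[C@@H]3COC[C@@H]32)cc2c1OC[C@H]2c1cccnc1` gives >= 104 ug/mL
- compound 2 `CNC(=O)c1cc(C(=O)N[C@H]2[C@@H]3COC[C@@H]32)cc2c1OC[C@H]2c1cccc2[nH]ccc12` gives >= 171 ug/mL
- compound 3 `CNC(=O)c1cc(C(=O)N[C@H]2[C@@H]3COC[C@@H]32)cc2c1OC[C@@]2(CO)c1ccccc1` gives >= 202 ug/mL

In a physicochemical assay for solubility (a higher number here means a more soluble compound, a lower number a less soluble compound), compound 1 gives >= 104 ug/mL, which is a limit and not a number. Compound 2 also reports only a limit, as does compound 3, so no exact reading is available for any of the three.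

Compound 4 `CNC(=O)c1cc(C(=O)N[C@H]2[C@@H]3COC[C@@H]32)cc2c1OC[C@H]2c1ccncc1` keeps the core of compound 1 and has pyridin-4-yl in place of pyridin-3-yl on a saturated ring carbon. The two have the same atoms, joined differently.

One measured change bears on this place: a step that the two limits leave unreadable from compound 1 to compound 2. Both its ends are limits, so it offers no size to carry over. With no measured size to suggest otherwise, no change beyond the scatter is expected in this assay, and so no direction is predicted. The expected change is a step that the limit leaves unreadable from compound 1 to compound 4.

For compound 4 the estimated value is 150 ug/mL, with an expected range of 80 ug/mL to 300 ug/mL.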

Compound 4, solubility: >= 184 ug/mL
Compound 4 gave a limit, no number; the forecaster's own chance of this, stated with the estimate: 70%; middle value at least 1.2-fold (0.08 log units) away from the limit.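

In this assay compound 4 gives >= 184 ug/mL, which is a limit. Its steps from compound 1 and from compound 2 also rest on limits at both ends and cannot be read. The compounds shown leave open how far apart their true values lie.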